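The source may report more compounds than this note shows. Statements on the series, on what has been measured and on what is new or still open speak of the compounds shown alone.

compound 1 `O=C1O/C(=C\Cn2cc(I)c(=O)[nH]c2=O)C(OCc2ccccc2)=C1OCc1ccccc1`: 5000 nM
compound 2 `O=C1O/C(=C\Cn2ccc(=O)[nH]c2=O)C(OCc2ccccc2)=C1OCc1ccccc1`: 20000 nM
compound 3 `O=C1O/C(=C\Cn2cc(Br)c(=O)[nH]c2=O)C(OCc2ccccc2)=C1OCc1ccccc1`: 5000 nM

In a functional assay on HEL cells (Homo sapiens) for cytotoxicity, read by microscopy (on this read-out higher numbers stand for weaker inhibition and lower numbers for stronger inhibition), compound 3 stands at 5000 nM, level with compound 1, and the two share the lowest number of the three. Compound 2 is the furthest from it, with a 4.0-fold lower number from compound 2 to compound 3 (0.60 log units; beyond the scatter), a modest step beyond the scatter.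

The next compound, compound 4 `O=C1O/C(=C\Cn2cc(F)c(=O)[nH]c2=O)C(OCc2ccccc2)=C1OCc1ccccc1`, carries fluoro in place of bromo on an aromatic carbon. For the measured compounds named here, no measured compound has fluoro there, so the evidence is indirect. Going by the values given here, the closest precedent is the exchange between the two heavier halogens, no change at the digits printed from compound 1 to compound 3 (within the scatter), which lies within the scatter. Among the compounds with values here, removing the halogen altogether is the only change that moved the number, with a 4.0-fold higher number from compound 1 to compound 2 (0.60 log units; beyond the scatter), and that step is also modest. On these three compounds, a halogen at this place goes with the lower number, whichever of the two was present. If fluoro follows bromo and iodo, no step beyond the scatter is expected in this assay, although a drift toward the value of compound 2, 20000 nM, cannot be excluded.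

The estimated step is a 1.2-fold higher number from compound 3 to compound 4 (0.08 log units; within the scatter), which is expected to stay within the scatter. Compound 4 is therefore expected at about 6000 nM, with an estimated range of 1500 nM to 20000 nM.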

Compound 4, half-maximal inhibitory concentration: 20000 nM
Estimate against measurement, compound 4: 3.3-fold (0.52 log units) below, within the range that was stated.
By their numbers in this assay, from the lowest: compounds 1 and 3 (each within the scatter of the next); then compounds 2 and 4 (each within the scatter of the next).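

In this assay the halogens at this place on the shared core no longer behave as one class, with a 4.0-fold higher number from compound 3 to compound 4 (0.60 log units; beyond the scatter) and, against the heavier halogen of the series, a 4.0-fold higher number from compound 1 to compound 4 (0.60 log units; beyond the scatter) as well. Fluoro also does not separate from hydrogen on this aromatic carbon, with no change at the digits printed from compound 2 to compound 4 (within the scatter) and thus the two compounds sitting together at the higher level, so among these four compounds the lower number goes with bromo and iodo only, and compound 4 goes against the earlier reading that any halogen at this place lowers the number. The data offered here contain no measurement that would account for why fluoro parts from bromo and iodo at this place.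

For the compounds shown here, what remains open is whether the lower number is confined to bromo and iodo or would also appear with chloro, methyl or trifluoromethyl at this place, since the series so far has only two levels and no intermediate case. On these data alone, it is also open whether the same ranking of iodo, bromo, fluoro and hydrogen would hold if the two benzyloxy groups of the shared core were replaced by hydroxyl groups.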